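The source may report more compounds than this note shows. Statements on the series, on what has been measured and on what is new or still open speak of the compounds shown alone.

Compound 2 `CC(C)c1onc(-c2c(Cl)cccc2Cl)c1COc1ccc(-c2nc3ccc(C(=O)O)cc3n2CC2CC2)cc1` gives 2650 nM in an assay on HEK-293T cells for antagonist activity at vitamin D3 receptor (Homo sapiens), read by a luciferase reporter, with a stated time of 24 h (a higher number here means a weaker inhibitor, a lower number a stronger inhibitor), the lowest of the two numbers shown, while compound 1 `CCn1c(-c2ccc(OCc3c(-c4c(Cl)cccc4Cl)noc3C(C)C)cc2)nc2ccc(C(=O)O)cc21` gives 5760 nM in this assay. Compound 3 `CC(=O)C1CCC(Cn2c(-c3ccc(OCc4c(-c5c(Cl)cccc5Cl)noc4C(C)C)cc3)nc3ccc(C(=O)O)cc32)CC1` reaches only a limit in this assay, > 10000 nM, as noted by the limit of > 10000 nM in this assay, at which 1 of the 3 values shown sits. The step to compound 4 `CC(C)c1onc(-c2c(Cl)cccc2Cl)c1COc1ccc(-c2nc3ccc(C(=O)O)cc3n2Cc2ccc(F)cc2)cc1` is 4-fluorophenyl in place of cyclopropyl on a saturated chain carbon bound to an aromatic nitrogen. Among the measured compounds shown here, two measured steps touch the same place: a 2.2-fold lower number from compound 1 to compound 2 (0.34 log units; beyond the scatter), and an at least 3.7-fold higher number from compound 2 to compound 3 (0.57 log units; beyond the scatter). They run in opposite directions, so a change at this carbon can move the number either way, and 4-fluorophenyl enters with more heavy atoms than cyclopropyl leaves. Compound 4 is therefore expected to land near compound 2 or somewhat weaker, a 1.3-fold higher number from compound 2 to compound 4 (0.12 log units; within the scatter). The estimate for compound 4 is 3500 nM, between 900 nM and 12000 nM.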

Compound 4, half-maximal inhibitory concentration: 1140 nM
Compound 4: middle estimate off by 3.1-fold (0.49 log units), on the high side; the measured number falls inside the stated range.
By their numbers in this assay, from the lowest: compound 4; then compound 2; then compound 1. At a limit, above all of these: compound 3.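

At this saturated chain carbon bound to an aromatic nitrogen, a group with an aromatic ring gives the lowest number yet: 4-fluorophenyl brings a 2.3-fold lower number from compound 2 to compound 4 (0.37 log units; beyond the scatter) and a 5.1-fold lower number from compound 1 to compound 4 (0.70 log units; beyond the scatter). More heavy atoms here therefore need not raise the number, and 4-acetylcyclohexyl in place of 4-fluorophenyl shows that the group's identity matters, read in reverse from an at least 8.7-fold lower number from compound 3 to compound 4 (0.94 log units; beyond the scatter). That comparison rests on a limit for compound 3: the limit of > 10000 nM in this assay, at which 1 of the 4 values shown sits.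

The compounds shown leave open whether the fluorine or the ring itself accounts for the step, which a plain benzyl would address. They also leave open how an amine on that ring would fare.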